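Compound 3: a new aryl group on the nitrogen

The source may report more compounds than this note shows. Statements on the series, on what has been measured and on what is new or still open speak of the compounds shown alone.

Compound 1 `COc1cc(C(=O)c2cn(-c3cccc(C)c3)cc2-c2ccccc2F)cc(OC)c1OC` gives 190 nM in a functional assay on MCF7 cells (Homo sapiens) for cytotoxicity, read by MTT assay, with a stated time of 96 h (on this read-out higher numbers stand for weaker inhibition and lower numbers for stronger inhibition), and compound 2 `COc1cc(C(=O)c2cn(-c3cccc(C)c3)cc2-c2ccccc2Cl)cc(OC)c1OC` gives 420 nM on the same read-out. Compound 2 therefore holds the higher of the two numbers.

Compound 3 `COc1cc(C(=O)c2cn(-c3ccc(N)cc3)cc2-c2ccccc2Cl)cc(OC)c1OC` keeps the 2-chlorophenyl group of compound 2 and carries 4-aminophenyl in place of 3-methylphenyl on an aromatic nitrogen.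

Going by the values given here, no measured step changes the group on that nitrogen. Among the compounds with values here, the only step available is a 2.2-fold higher number from compound 1 to compound 2 (0.34 log units; beyond the scatter) for chloro in place of fluoro on an aromatic carbon, a modest step at a different place. It offers a rough scale for this series and no direction for the new exchange. A step somewhat larger than that one is expected, with only a slight lean towards a lower number and a real chance of the opposite.

The expected change in this assay is a 2.8-fold lower number from compound 2 to compound 3 (0.45 log units; beyond the scatter) as a tentative estimate. For compound 3 the estimated value is 150 nM (30 nM to 600 nM).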

Compound 3, half-maximal inhibitory concentration: 83 nM
The estimate for compound 3 lay 1.8-fold (0.26 log units) above the measured number; low and high end bracket the measured number.
By their numbers in this assay, from the lowest: compound 3; then compound 1; then compound 2.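

With the 2-chlorophenyl group held constant, the group on the aromatic nitrogen proves to be a working point of change in this assay: 4-aminophenyl in place of 3-methylphenyl gives a 5.1-fold lower number from compound 2 to compound 3 (0.70 log units; beyond the scatter). This is a larger step than the only earlier one, a 2.2-fold higher number from compound 1 to compound 2 (0.34 log units; beyond the scatter), and it comes from an exchange that leaves the heavy-atom count unchanged while adding a hydrogen-bond donor and a hydrogen-bond acceptor. No measurement on hand accounts for the step.

The single exchange removes the methyl group and introduces the amine at a different ring position, so the compounds shown do not separate the contribution of the amine from that of the lost methyl or of the changed position. Still open, as far as these compounds go, are whether a hydroxyl or a methoxy group in place of the amine gives a similar number in this assay, and whether the 4-aminophenyl group gives a step of similar size when paired with the 2-fluorophenyl group of compound 1.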